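The source may report more compounds than this note shows. Statements on the series, on what has been measured and on what is new or still open speak of the compounds shown alone.

Compound 1 `Fc1ccc(Nc2cc3[nH]c(-c4cccc(C(F)(F)F)c4)nc3cn2)nc1` — in a physicochemical assay for solubility, using the shake flask method, in simulated intestinal fluid, measured as kinetic solubility, with a stated time of 20 h, at pH 6.5 (a higher number here means a more soluble compound, a lower number a less soluble compound), compound 1 gives >= 50000 nM, which is a limit of the assay.
Compound 2 `FC(F)(F)c1ccc(Nc2cc3[nH]c(-c4cccc(C(F)(F)F)c4)nc3cn2)nc1` — in this assay compound 2 gives >= 50000 nM, which is also a limit of the assay.

Compound 2 therefore stands at the limit of >= 50000 nM in this assay, at which 2 of the 2 values shown sit, so its place among the numbers shown is a limit rather than a measured point. Among the compounds with values here, the single measured step, a step that the two limits leave unreadable from compound 1 to compound 2, is left unreadable by the two limits. Compound 3 `O=C(O)c1ccc(Nc2cc3[nH]c(-c4cccc(C(F)(F)F)c4)nc3cn2)nc1` differs from compound 2 by carboxy in place of trifluoromethyl on an aromatic carbon. Within the data shown here, the only step that bears on this change is the one already described, and its size cannot be read, so no direction beyond the scatter can be drawn from it. Compound 3 is thus expected to give 50000 nM in this assay, within a range from 20000 nM to 200000 nM. This estimate means a number no higher from compound 2 to compound 3 (the limit leaves the size open), a step expected to stay within the scatter, with both compounds likely reported at the limit.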

Compound 3, solubility: 6000 nM
For compound 3 the middle estimate is 8.3-fold (0.92 log units) above the measured one, outside the stated range (below it).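

In this assay, this position, an aromatic carbon two atoms from the ring nitrogen and para to a large group, now shows that its substituent can change the read-out. Carboxy in place of trifluoromethyl gives an at least 8.3-fold lower number from compound 2 to compound 3 (0.92 log units; beyond the scatter), and carboxy in place of fluoro gives an at least 8.3-fold lower number from compound 1 to compound 3 (0.92 log units; beyond the scatter). Both sizes are only minimums, and the step between fluoro and trifluoromethyl cannot be read: the limit of >= 50000 nM in this assay, at which 2 of the 3 values shown sit.

The compounds shown leave open whether the lower number is particular to carboxy or would also come with a primary amide, a methyl ester or an amine at this position. They also leave open whether carboxy placed elsewhere on the shared core would give a step of similar size.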